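This account rests on a few compounds, and the source may have more. Where it says the series, first, only, none or still open, it means among the compounds named here.

Compound 1 `CCCCCCCC[C@@]1(C)SC(=O)C=C1OCC(=O)OCC` value 35.3 ug/mL
Compound 2 `CCCCCCCC[C@@]1(C)SC(=O)C=C1OC(=O)OC` value 21.6 ug/mL

Among the compounds with values here, in a functional assay on MCF7 cells (Homo sapiens) for inhibition, read by radiometric assay and XTT assay (on this read-out lower numbers stand for stronger inhibition and higher numbers for weaker inhibition), compound 2 gives 21.6 ug/mL and sits within the usual scatter of compound 1, with a 1.6-fold lower number from compound 1 to compound 2 (0.21 log units; within the scatter) as the only measured step so far. Compound 3 `C=CCOC(=O)OC1=CC(=O)S[C@]1(C)CCCCCCCC` has not yet been measured. Its change from compound 2 is vinyl in place of hydrogen on a saturated chain carbon bound to an oxygen next to a carbonyl group and reads as vinyl in place of hydrogen on a saturated chain carbon bound to an oxygen next to a carbonyl group, so methoxycarbonyl becomes allyloxycarbonyl. Within the data shown here, the single measured step also altered this same group, and it stayed within the scatter, which is thin but real guidance. In this assay no shift beyond the scatter is therefore expected, and the estimated move is a 1.2-fold higher number from compound 2 to compound 3 (0.06 log units; within the scatter) at most a small one. For compound 3 the estimated value is 25 ug/mL with an expected range from 12 ug/mL to 50 ug/mL on this read-out.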

Compound 3, half-maximal inhibitory concentration: 37.3 ug/mL
Beside the measured number, compound 3's estimate is 1.5-fold (0.17 log units) below it, and the stated range covers the measured number.
By their numbers in this assay, from the lowest: compounds 2, 1 and 3 (each within the scatter of the next).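

In this assay, the step of a 1.7-fold higher number from compound 2 to compound 3 (0.24 log units; within the scatter) comes with vinyl in place of hydrogen on a saturated chain carbon bound to an oxygen next to a carbonyl group, and the step of a 1.1-fold higher number from compound 1 to compound 3 (0.02 log units; within the scatter) comes with allyloxycarbonyl in place of (ethoxycarbonyl)methyl. This position has now carried three different groups, and every step among them stays within the scatter, so the added vinyl shows no measurable effect on this read-out. Nothing available explains why the three numbers sit so close.

As far as these compounds go, it remains open whether a different kind of group on this oxygen, such as an amine or a carboxylic acid, would give a step beyond the scatter. From the compounds shown here alone, the saturated chain on the shared core is the same in all three compounds, so the effect of a shorter chain there also remains open.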